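The compounds below may be only part of what the source reports. "The series", "measured", "known", "first", "only" and "open" are said of these compounds alone.

In a functional assay on PC-3 cells (Homo sapiens) for cytotoxicity, read by MTT assay, with a stated time of 24 h (on this read-out lower numbers stand for stronger inhibition and higher numbers for weaker inhibition), compound 1 `Cc1ccc(/C=C2\CN(Cc3cn(Cc4ccc(F)cc4)nn3)C/C(=C\c3ccc(C)cc3)C2=O)cc1` gives 65600 nM and compound 3 `COc1ccc(/C=C2\CN(C(=S)SCc3cn(Cc4ccccc4Cl)nn3)C/C(=C\c3ccc(OC)cc3)C2=O)cc1` gives 60100 nM as its reading, two numbers that lie within the usual scatter of each other. Compound 2 `Cc1ccc(/C=C2\CN(C(=S)SCc3cn(Cc4cccc(Cl)c4)nn3)C/C(=C\c3ccc(C)cc3)C2=O)cc1` returned > 80000 nM as a limit of the assay and not a number. Compound 4 `Cc1ccc(/C=C2\CN(Cc3cn(Cc4ccccc4Cl)nn3)C/C(=C\c3ccc(C)cc3)C2=O)cc1` is still unmeasured and differs from compound 1 in a single place: 2-chlorophenyl in place of 4-fluorophenyl on a saturated chain carbon bound to an aromatic nitrogen which means 2-chlorophenyl in place of 4-fluorophenyl on a saturated chain carbon bound to an aromatic nitrogen. Within the data shown here, no measured pair isolates this change. Compound 3 also carries 2-chlorobenzyl and gives 60100 nM so no step beyond the scatter is expected in this assay in either direction. The expected step is a 1.1-fold lower number from compound 1 to compound 4 (0.04 log units; within the scatter) and stays within the scatter. Compound 4 is estimated at 60000 nM with an expected range from 30000 nM to 80000 nM when it is measured.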

Compound 4, half-maximal inhibitory concentration: 8900 nM
The estimate for compound 4 lay 6.7-fold (0.83 log units) above the measured number, and the stated range ends above it.
By their numbers in this assay, from the lowest: compound 4; then compounds 3 and 1 (each within the scatter of the next). At a limit, above all of these: compound 2.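

In this assay, 2-chlorophenyl in place of 4-fluorophenyl on a saturated chain carbon bound to an aromatic nitrogen gives a 7.4-fold lower number from compound 1 to compound 4 (0.87 log units; beyond the scatter). Among these compounds, this pair is the first to isolate a change at this place, and it shows that the number responds to the aryl group there, even with the same count of heavy atoms. Nothing measured here accounts for the step.

The change swaps both the halogen and its place on the ring, so this pair cannot separate the two. 2-Fluorophenyl and 4-chlorophenyl would be needed to tell them apart.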